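This account rests on a few compounds, and the source may have more. Where it says the series, first, only, none or still open, it means among the compounds named here.

Measured in a functional assay on NALM-6 cells (Homo sapiens) for cytotoxicity, read by MTT assay, with a stated time of 48 h; on this read-out higher numbers stand for weaker inhibition and lower numbers for stronger inhibition:
Compound 1 `C=C1C(=O)O[C@H](C)[C@@H]1c1ccc(Br)cc1` gives 4250 nM.
Compound 2 `C=C1C(=O)O[C@H](C)[C@@H]1c1ccc(OC)cc1` gives 5590 nM.

Compound 2 shows the higher of the two numbers in this assay, but the step of a 1.3-fold higher number from compound 1 to compound 2 (0.12 log units; within the scatter) is within the scatter, so the two compounds cannot be told apart. Compound 3 `C=C1C(=O)O[C@H](C)[C@@H]1c1ccc(C)cc1` differs from compound 2 by methyl in place of methoxy on an aromatic carbon. No measured step involves this change; the only step shown, a 1.3-fold higher number from compound 1 to compound 2 (0.12 log units; within the scatter), concerns the same position and lies within the scatter. Compound 3 is therefore expected to show a step of a 1.1-fold lower number from compound 2 to compound 3 (0.05 log units; within the scatter), not beyond the scatter. Compound 3 is estimated at 5000 nM, with a range from 2500 nM to 10000 nM.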

Compound 3, half-maximal inhibitory concentration: 5970 nM
Estimate against measurement, compound 3: 1.2-fold (0.08 log units) below, and the stated range covers the measured number.
By their numbers in this assay, from the lowest: compounds 1, 2 and 3 (each within the scatter of the next).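

Methyl in place of methoxy on this aromatic carbon, tested in this assay, leaves the result within the scatter (a 1.1-fold higher number from compound 2 to compound 3 (0.03 log units; within the scatter)). Methyl in place of bromo does the same (a 1.4-fold higher number from compound 1 to compound 3 (0.15 log units; within the scatter)). This position has now carried bromo, methoxy and methyl without the three compounds being told apart, even though methyl brings no hydrogen-bond acceptor where methoxy has one, and no measured evidence here accounts for this. The compounds shown leave open whether an amine, a carboxylic acid or a longer chain at this position would give a step beyond the scatter.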